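From Methyl to Methoxy on a Thinly Measured Series

A few compounds are considered here, and "the series" means these few. Any claim that something is new, unique, unknown or untested is made for them only; others in the source may bear on it.

Measured in a functional assay on HeLa cells (Homo sapiens) for antiproliferative activity, read by MTT assay, with a stated time of 72 h; on this read-out higher numbers stand for weaker inhibition and lower numbers for stronger inhibition:
Compound 1 `COc1cc(-c2ncnn2-c2cccc(F)c2)cc(OC)c1OC`: > 10000 nM (a limit)
Compound 2 `COc1cc(-n2ncnc2-c2ccc(C)cc2)cc(OC)c1OC`: 250 nM
Compound 3 `COc1cc(-c2ncnn2-c2ccc(Cl)cc2Cl)cc(OC)c1OC`: > 10000 nM (a limit)

Compound 2 alone carries an actual number. What else is known is the limit of > 10000 nM in this assay, at which 2 of the 3 values shown sit. Compound 4 `COc1ccc(-c2ncnn2-c2cc(OC)c(OC)c(OC)c2)cc1` departs from compound 2 in one place: methoxy in place of methyl on an aromatic carbon, with methoxy in place of methyl on an aromatic carbon. For the measured compounds named here, the only measured step, a step that the two limits leave unreadable from compound 1 to compound 3, offers no size to carry over. The expectation therefore rests on compound 2 at 250 nM, and a modest move toward stronger inhibition in this assay is tentatively expected. The expected change is a 2.5-fold lower number from compound 2 to compound 4 (0.40 log units; beyond the scatter). For compound 4 the estimated value is 100 nM, within an expected range of 12 nM to 800 nM.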

Compound 4, half-maximal inhibitory concentration: 280 nM
Estimate against measurement, compound 4: 2.8-fold (0.45 log units) below, within the range that was stated.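

In this assay, the change from 4-methylphenyl to 4-methoxyphenyl gives a 1.1-fold higher number from compound 2 to compound 4 (0.05 log units; within the scatter). For the compounds shown here, this is the first step with a readable size, and it shows that at this place, para to a large group, methoxy and methyl cannot be told apart on this read-out. Nothing shown gives a reason for this result.

As far as these compounds go, whether an amine, a carboxylic acid or a longer chain such as butyl would be accommodated equally at this place remains open. So does whether a hydroxyl group would match methoxy there.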